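This account rests on a few compounds, and the source may have more. Where it says the series, first, only, none or still open, it means among the compounds named here.

Working notes on the series.

Compound 1 `COc1cc2nc(C3CCC3)nc(N3CCN(c4ccccc4)CC3)c2cc1OC` carries a cyclobutyl on the shared core and a plain phenyl on the piperazine. In an in vitro assay on U2OS cells for agonist activity at neurotensin receptor type 2 (Homo sapiens), read by reporter gene assay and beta-arrestin recruitment (a lower number here means that less compound is needed, a higher number that more compound is needed for the effect), compound 1 sits at the limit of the assay, > 80000 nM, and this is a limit, not a number. Compound 2 `COc1cc2nc(C3CCC3)nc(N3CCN(c4ccccc4Cl)CC3)c2cc1OC` differs from it by chloro in place of hydrogen on an aromatic carbon; in this assay compound 2 also gives only a limit, > 80000 nM. The step that the two limits leave unreadable from compound 1 to compound 2 therefore cannot be read. Compound 3 `COc1cc2ncnc(N3CCN(c4ccccc4OC)CC3)c2cc1OC` lacks the cyclobutyl and carries methoxy on the phenyl; in this assay compound 3 again returns a limit, > 80000 nM. Where compound 3 stands is thus known only as a limit, and the same holds for both other values shown, which is the substance of the limit of > 80000 nM in this assay, at which 3 of the 3 values shown sit.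

Compound 4 `COc1cc2nc(C(C)C)nc(N3CCN(c4ccccc4OC)CC3)c2cc1OC` differs from compound 3 by isopropyl in place of hydrogen on an aromatic carbon. No measured step reads on this change; the one step shown is unreadable from both ends, and the compounds that carry a cycloalkyl at the same place, compound 1 and compound 2, sit at the limit as compound 3 does. No step beyond the scatter is expected, and a step that the limit leaves unreadable from compound 3 to compound 4 is the estimate. Compound 4 is expected at 100000 nM, within 30000 nM to 300000 nM, most likely again reported only as a limit.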

Compound 4, half-maximal effective concentration: > 80000 nM
Compound 4 ended at the assay's limit (the forecaster's own chance of this, stated with the estimate: 85%); the middle value lies beyond the limit too.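

The step from compound 3 to compound 4 cannot be read, as both compounds return only a limit in this assay, and the isopropyl adds no readable information: the limit of > 80000 nM in this assay, at which 4 of the 4 values shown sit.

The compounds shown leave open which change to the shared core or the phenyl, if any, would give a number in this assay rather than a limit.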